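Second methyl on the fused ring of compound 2

The source may hold more compounds than are shown below. What is called first, only, known or untested is meant among the compounds shown, and "the series" means these compounds.

Measured so far:
compound 1 `CCc1cc(CCc2nc3cccc(F)c3o2)c(O)nc1C`: 8160 nM
compound 2 `CCc1cc(CCc2nc3c(C)cccc3o2)c(O)nc1C`: 2450 nM

In a functional assay on a cell-free system (plasma, Homo sapiens) for acid dissociation (on this read-out higher numbers stand for weaker binding and lower numbers for tighter binding), compound 2 gives 2450 nM, the lowest of the two numbers. Compound 1 gives 8160 nM in this assay, a gap beyond the usual scatter. Compound 3 `CCc1cc(CCc2nc3c(C)ccc(C)c3o2)c(O)nc1C` differs from compound 2 only by methyl in place of hydrogen on an aromatic carbon. Within the data shown here, no step between measured compounds is available for this change, so the expectation rests on compound 2 alone. A small step from compound 2 to compound 3 is expected, a 1.4-fold lower number from compound 2 to compound 3 (0.13 log units; within the scatter), toward a lower number or none beyond the scatter. Compound 3 is therefore estimated at 1800 nM in this assay, with a range from 600 nM to 5500 nM.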

Compound 3, dissociation constant: 1210 nM
Compound 3: the middle estimate sits 1.5-fold (0.17 log units) above what was measured; low and high end bracket the measured number.
By their numbers in this assay, from the lowest: compound 3; then compound 2; then compound 1.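

In this assay methyl in place of hydrogen on this aromatic carbon, para to a methyl group, gives a 2.0-fold lower number from compound 2 to compound 3 (0.31 log units; beyond the scatter) and shows that this position takes one more heavy atom with a modest move toward tighter binding. Among these compounds, the step is the first reading at this position, and it rests on a single pair. Nothing measured on these compounds accounts for the step. On these data alone, whether a longer chain such as ethyl, or an amine or a carboxylic acid, on the same carbon would extend, keep or reverse this step remains open.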